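Limits across the series so far

The compounds below may be only part of what the source reports. "The series", "measured", "known", "first", "only" and "open" are said of these compounds alone.

In an ADME assay on DG-75 cells (Homo sapiens) for cytotoxicity, read by MTT assay, with a stated time of 120 h (a lower number here means a stronger inhibitor, a higher number a weaker inhibitor), all values are limits:
- Compound 1 `N#C[C@H]1[C@H](O)[C@@H](CO)O[C@H]1n1cnc2c(Cl)nc(N)nc21` gives > 15000 nM as a limit
- Compound 2 `N#C[C@H]1[C@H](O)[C@@H](CO)O[C@H]1n1cnc2c(N)nc(N)nc21` gives > 15000 nM as a limit
- Compound 3 `N#C[C@H]1[C@H](O)[C@@H](CO)O[C@H]1n1cnc2c(O)nc(N)nc21` gives > 15000 nM as a limit

Compound 3 stands at > 15000 nM in this assay and this is a limit. The whole series rests on the limit of > 15000 nM in this assay, at which 3 of the 3 values shown sit, and offers no readable number. The change to compound 4 `COc1nc(N)nc2c1ncn2[C@@H]1O[C@H](CO)[C@@H](O)[C@@H]1C#N` is methyl in place of hydrogen on an oxygen on an aromatic ring and reads as hydroxy to methoxy. Within the data shown here, the steps that bear on it are a step that the two limits leave unreadable from compound 2 to compound 3 and a step that the two limits leave unreadable from compound 1 to compound 3 and neither gives a size. No step beyond the scatter is therefore expected in this assay and no direction can be set. The expected step is a number no higher from compound 3 to compound 4 (the limit leaves the size open) for now. Compound 4 is expected at 15000 nM within an estimated range of 5000 nM to 30000 nM and may well return as a limit too.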

Compound 4, half-maximal inhibitory concentration: > 15000 nM
Compound 4 ended at the assay's limit; the forecaster's own chance of this, stated with the estimate: 70%; the middle value sits exactly at the limit.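

In this assay no new step can be read for compound 4 against compound 1, compound 2 or compound 3, as all rest on one limit: the limit of > 15000 nM in this assay, at which 4 of the 4 values shown sit.

The compounds shown leave open whether any group at this aromatic carbon gives a readable number.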